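The compounds below may be only part of what the source reports. "The series", "measured", "known", "first", "only" and "open" are said of these compounds alone.

Measured so far:
- compound 1, `CCCCOc1ccc(C(=O)Nc2cccc(C(=O)O)c2)cc1`: 105 nM
- compound 2, `CCCCOc1cccc(-c2cccc(C(=O)Nc3cccc(C(=O)O)c3)c2)c1`: 256 nM

In an assay on isolated protein for agonist activity at Bile acid receptor (Homo sapiens), read by TR-FRET, with a stated time of 3 h, in the absence of a further agent (on this read-out higher numbers stand for an effect only at larger amounts of compound and lower numbers for an effect already at smaller amounts), compound 1 gives 105 nM and compound 2 gives 256 nM, so compound 2 stands at the higher of the two numbers, its gap to compound 1 beyond the scatter. Compound 3, `O=C(O)c1cccc(NC(=O)c2cccc(-c3cccc(OCc4ccccc4)c3)c2)c1`, differs from compound 2 by phenyl in place of propyl on a saturated chain carbon bound to an oxygen on an aromatic ring. Going by the values given here, no measured pair shows this change, so in this assay no step beyond the scatter is expected in either direction. Compound 3 is therefore estimated at 300 nM, expected between 100 nM and 900 nM. The expected step is a 1.2-fold higher number from compound 2 to compound 3 (0.07 log units; within the scatter).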

Compound 3, half-maximal effective concentration: 189 nM
The estimate for compound 3 lay 1.6-fold (0.20 log units) above the measured number, and the stated range covers the measured number.
By their numbers in this assay, from the lowest: compounds 1, 3 and 2 (each within the scatter of the next, the first and the last beyond it).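

In this assay, phenyl in place of propyl on a saturated chain carbon bound to an oxygen on an aromatic ring, read as butoxy to benzyloxy, gives a 1.4-fold lower number from compound 2 to compound 3 (0.13 log units; within the scatter) and so no step beyond the scatter. In this pair, the position accepts a terminal aromatic ring as well as an open chain. Nothing available explains why the two groups read alike.

On these data alone, whether the same change holds on the core of compound 1 remains open. So does how a longer chain such as hexyl, or an amine at the chain end, would read.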